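This account rests on a few compounds, and the source may have more. Where it says the series, first, only, none or still open, it means among the compounds named here.

Working notes on the series. Compound 1 `COc1ccc(OC)c(C2OC(c3cc(OC)c(OC)c(OC)c3)=NN2C(C)=O)c1` is the cyclic analogue among the three measured compounds; the two open-chain hydrazones are compound 2 `COc1cc(C(=O)N/N=C/c2ccc(C(F)(F)F)cc2)cc(OC)c1OC` and compound 3 `COc1cc(C(=O)N/N=C/c2ccc(Cl)c([N+](=O)[O-])c2)cc(OC)c1OC`. In a functional assay on BGC-823 cells (Homo sapiens) for antiproliferative activity, read by MTT assay, tested at 5 uM (on this read-out lower numbers stand for a weaker effect and higher numbers for a stronger effect at the one concentration tested), compound 1 gives 18.2%, the second highest of the three numbers. The nearest number is that of compound 3, which gives 2.3% in this assay, a gap beyond the scatter. The furthest is compound 2, which gives 56.3% in this assay, also beyond the scatter, in the other direction. No pair among these three differs in one place only, so no single-step comparison is available within the measured set.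

Compound 4 `COc1cc(C2=NN(C(C)=O)C(c3ccc(F)c(F)c3)O2)cc(OC)c1OC` is not yet measured. It differs from compound 1 in one place: 3,4-difluorophenyl in place of 2,5-dimethoxyphenyl on a saturated ring carbon. Among the compounds with values here, with no measured step of this kind to lean on, the expectation is a step in this assay of small size, if any, and not clearly beyond the scatter in either direction; the change from compound 1 to compound 4 is estimated as a number 3.8 percentage points higher from compound 1 to compound 4 (within the scatter). Compound 4 is therefore expected to give about 22% in this assay, with a range from 6% to 42%.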

Compound 4, a percentage reported as inhibition, at one concentration (the size of the read-out at that concentration, not a potency): 21.6%
Compound 4: middle estimate off by 0.4 percentage points, on the high side; the range from low to high includes it.
By their numbers in this assay, from the lowest: compound 3; then compounds 1 and 4 (each within the scatter of the next); then compound 2.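

In this assay the series now has its first single-place comparison: 3,4-difluorophenyl in place of 2,5-dimethoxyphenyl on the saturated ring carbon gives a number 3.4 percentage points higher from compound 1 to compound 4 (within the scatter), so this pair does not separate the two aryl groups. The step holds even though the entering group has different ring substituents and lacks the hydrogen-bond acceptors of the leaving group, although this rests on one pair and one concentration. No available evidence bears on this result.

As far as these compounds go, it remains open whether a non-aryl group on this carbon, such as an amine, a carboxylic acid or a longer alkyl chain, would give a step beyond the scatter. Within the data shown here, no single-place pair yet links the cyclic compounds to the open-chain hydrazones, so the role of the ring itself also remains open.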